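Sulfonyl aryl variation in a trifluoromethyl hydroxyamide series

This account rests on a few compounds, and the source may have more. Where it says the series, first, only, none or still open, it means among the compounds named here.

The two measured compounds share one core and differ in the aryl on the sulfonyl sulfur and in the central ring. Compound 1 `CC(O)(C(=O)Nc1ccc(S(=O)(=O)c2ccccc2F)cc1)C(F)(F)F` carries a 2-fluorophenyl on the sulfonyl sulfur; in a functional assay (Cavia porcellus) with sulfonylurea receptors; K-ATP channels (Homo sapiens) as the target (on this read-out higher numbers stand for weaker inhibition and lower numbers for stronger inhibition), compound 1 gives 1300 nM. Compound 2 `CC(O)(C(=O)Nc1ccc(S(=O)(=O)c2ccccc2)c(O)c1)C(F)(F)F` differs from compound 1 in more than one place, and in this assay compound 2 gives 430 nM. For the measured compounds named here, compound 1 thus stands at the highest of the two numbers so far, with compound 2 lying lower by an amount beyond the scatter; no single-change step links the two, so only the two values themselves are stated.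

Compound 3 `Cc1cccc(S(=O)(=O)c2ccc(NC(=O)C(C)(O)C(F)(F)F)cc2)c1` is not yet measured. Relative to compound 1 it carries 3-methylphenyl in place of 2-fluorophenyl on a sulfonyl sulfur. Going by the values given here, no measured pair shows how a change of the aryl on the sulfonyl sulfur alone moves the number, so there is no direct precedent for this step. The expected step from compound 1 to compound 3 is a 1.2-fold lower number from compound 1 to compound 3 (0.07 log units; within the scatter), close to the scatter and without a clear direction. For compound 3 in this assay the estimate is 1100 nM, with a range from 400 nM to 3200 nM.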

Compound 3, half-maximal inhibitory concentration: 2200 nM
Estimate against measurement, compound 3: 2.0-fold (0.30 log units) below; the measured number falls inside the stated range.
By their numbers in this assay, from the lowest: compound 2; then compounds 1 and 3 (each within the scatter of the next).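

For the compounds shown here, the pair gives the first single-change reading on the sulfonyl sulfur: in this assay, 3-methylphenyl in place of 2-fluorophenyl gives a 1.7-fold higher number from compound 1 to compound 3 (0.23 log units; within the scatter) with the rest of the core of compound 1 held constant. This exchange therefore leaves the read-out within the scatter, and on this one pair it sets no direction for the aryl on the sulfonyl sulfur. The step also changes both the substituent and its place on the aryl, so this single comparison cannot assign any part of the reading to either; no measurement shown here bears on the reason for the result.

Still open, from the compounds shown here alone, is how 3-fluorophenyl or 2-methylphenyl on the sulfonyl sulfur would read against compound 1 and compound 3, since those two groups would separate the kind of substituent from its place on the aryl. Also open, going by these compounds, is whether an aminophenyl or a carboxyphenyl on the same sulfur would give a step beyond the scatter, which neither 2-fluorophenyl nor 3-methylphenyl can indicate.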